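Methyl on the Ring Nitrogen of a Weak Cytotoxic Amide

The source may hold more compounds than are shown below. What is called first, only, known or untested is meant among the compounds shown, and "the series" means these compounds.

Compound 1 `O=C(Nc1ccc(Oc2ccnc3[nH]ccc23)c(F)c1)c1nn(-c2ccc(Cl)cc2)ccc1=O` is a pyrazolone amide joined through an ether link to a fused bicyclic system. In a functional assay on A549 cells (Homo sapiens) for cytotoxicity, read by MTT assay, with a stated time of 72 h (on this read-out lower numbers stand for stronger inhibition and higher numbers for weaker inhibition), compound 1 reaches only the limit of the assay, > 60000 nM. Within the data shown here, its one measured neighbour is compound 2 `O=C(Nc1ccc(Oc2ccnc3[nH]ccc23)c(F)c1)c1nn(-c2ccc(Cl)c(F)c2)ccc1=O`, which carries an extra fluoro on the aromatic ring bearing the chloro; in this assay compound 2 gives 10300 nM. The change amounts to an at least 5.8-fold lower number from compound 1 to compound 2 (0.76 log units; beyond the scatter), a step that cannot be sized exactly because compound 1 sits at the limit (the limit of > 60000 nM in this assay, at which 1 of the 2 values shown sits).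

Compound 3 `Cn1ccc2c(Oc3ccc(NC(=O)c4nn(-c5ccc(Cl)cc5)ccc4=O)cc3F)ccnc21` differs from compound 1 elsewhere: methyl in place of hydrogen on an aromatic nitrogen. Among the measured compounds shown here, no measured step touches this position, so the fluoro step from compound 1 to compound 2 offers no direct guide to what a methyl on the ring nitrogen will do. With the parent already at the limit of the assay, the outlook for compound 3 is that it is expected to stay weak, giving an estimated 60000 nM within 20000 nM and 200000 nM. That corresponds to an expected step of a number no higher from compound 1 to compound 3 (the limit leaves the size open), most likely none beyond the scatter.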

Compound 3, half-maximal inhibitory concentration: > 60000 nM
Compound 3: no number, only a limit; the forecaster's own chance of this, stated with the estimate: 60%; the middle value lies on the limit itself.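

Compound 1 and compound 3 both stop at the limit of the assay rather than giving a number, so no step between them can be read: the limit of > 60000 nM in this assay, at which 2 of the 3 values shown sit.

The compounds shown leave open whether methyl in place of hydrogen on an aromatic nitrogen changes the result in this assay at all, including on a stronger compound such as compound 2.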